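The compounds below may be only part of what the source reports. "The series", "measured", "known", "first", "only" and "open" are said of these compounds alone.

Measured compounds in a functional assay on HepG2 cells (Homo sapiens) for antiproliferative activity, read by MTT assay; on this read-out higher numbers stand for weaker inhibition and lower numbers for stronger inhibition:
compound 1 `CNC(=O)c1ccc(Oc2cccc(NC(=S)Nc3cc(C(F)(F)F)cc(C(F)(F)F)c3)c2)nc1`, giving 4550 nM
compound 2 `CNC(=O)c1ccc(Oc2cccc(NC(=S)Nc3ccc(F)c(C(F)(F)F)c3)c2)nc1`, giving 20200 nM
compound 3 `CNC(=O)c1ccc(Oc2cccc(NC(=S)Nc3ccc(Cl)cc3Cl)c2)nc1`, giving 21600 nM

Compound 3 stands at the highest of the three numbers in this assay. Compound 2 sits within the scatter of compound 3, so no order between the two can be read. Compound 1 lies beyond the scatter from compound 3, with a clearly lower number, and is the only one of the three that separates from the rest.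

The step under consideration goes from compound 3 to compound 4 `CNC(=O)c1ccc(Oc2cccc(NC(=S)Nc3ccc(C)cc3)c2)nc1`. The change is 4-methylphenyl in place of 2,4-dichlorophenyl on an amide-type nitrogen. For the measured compounds named here, no measured pair shows this change, so its size is unknown from the series itself. Going by the values given here, the three measured compounds all carry halogenated aryl groups on that nitrogen, and the one that gives the lowest number, compound 1, carries two trifluoromethyl groups; the single example with a plain methyl-substituted aryl has no precedent here.

On this basis, compound 4 is expected to stay close to compound 3, with a step from a 1.2-fold higher number from compound 3 to compound 4 (0.08 log units; within the scatter) of no clear direction beyond the scatter, and possibly a somewhat higher number. The estimate for compound 4 in this assay is 26000 nM, in a range from 8000 nM to 80000 nM.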

Compound 4, half-maximal inhibitory concentration: 65400 nM
The estimate for compound 4 lay 2.5-fold (0.40 log units) below the measured number; measured number inside the range.
By their numbers in this assay, from the lowest: compound 1; then compounds 2 and 3 (each within the scatter of the next); then compound 4.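

In this assay, for the compounds shown here, 4-methylphenyl in place of 2,4-dichlorophenyl on the amide-type nitrogen gives a 3.0-fold higher number from compound 3 to compound 4 (0.48 log units; beyond the scatter), the first step at this position that can be read from a pair differing in one place. Going by these compounds alone, the read-out therefore responds to the aryl group at this nitrogen by more than the scatter, a point the earlier compounds could not show because each differed from the others in its substitution pattern without forming such a pair. Nothing available explains the size or direction of this step, so it stands as an observation without a cause.

Going by these compounds, the step removes two chlorine atoms and adds a methyl group in a single change, so the share of each remains open; plain phenyl and 4-chlorophenyl on the same nitrogen would be the groups that separate those contributions. Also open is whether an aryl group carrying an amine or a carboxylic acid at this position would follow the same direction, since all the aryl groups shown carry only halogen, trifluoromethyl or methyl substituents.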